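Diaryl sulfone amides: a benzyl urea replaces a propanamide

A few compounds are considered here, and "the series" means these few. Any claim that something is new, unique, unknown or untested is made for them only; others in the source may bear on it.

Measured compounds:
compound 1 `CCC(=O)Nc1ccc(S(=O)(=O)c2ccc(N)cc2)cc1`, 70.6%
compound 2 `CCCC(=O)Nc1ccc(S(=O)(=O)c2ccc(NC(=O)CCC)cc2)cc1`, 44.1%

In an assay on isolated protein for inhibition of protein arginine N-methyltransferase 1 (Homo sapiens), read by ELISA, tested at 50 uM (a lower number here means a weaker effect, a higher number a stronger effect of the compound at the concentration tested), compound 1 gives 70.6%, the higher of the two numbers; compound 2 sits well below it, beyond the usual scatter. Compound 3 `Nc1ccc(S(=O)(=O)c2ccc(NC(=O)NCc3ccccc3)cc2)cc1` keeps the free amine side of compound 1 and changes the other side: benzylamino in place of ethyl on a carbonyl carbon. Among the measured compounds shown here, no measured pair shows this exact change. A modest weakening or no shift beyond the scatter seems most likely in this assay, so the step of a number 10.6 percentage points lower from compound 1 to compound 3 (beyond the scatter) is expected to be small. Compound 3 is therefore estimated at 60%, within 35% to 85%.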

Compound 3, a percentage reported as inhibition, at one concentration (the size of the read-out at that concentration, not a potency): 13.6%
For compound 3 the middle estimate is 46.4 percentage points above the measured one; measured number below the stated range.
By their numbers in this assay, from the lowest: compound 3; then compound 2; then compound 1.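

In this assay, benzylamino in place of ethyl on a carbonyl carbon gives a number 57 percentage points lower from compound 1 to compound 3 (beyond the scatter). This step shows that the group on this carbonyl carbon can strongly change the read-out with the free amine side left unchanged, and that this larger group with its ring is poorly tolerated here. Nothing measured here explains the drop.

On these data alone, the change adds a ring and an amide-type nitrogen at once, so their separate contributions stay open. A methylamino group or a plain benzyl group on the same carbonyl carbon would help tell them apart.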